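Compound 2 to compound 4: bromo for trifluoromethyl

The source may report more compounds than this note shows. Statements on the series, on what has been measured and on what is new or still open speak of the compounds shown alone.

Within the data shown here, in an ADME assay on MDBK cells (Bos taurus) for cytotoxicity, read by MTT assay, with a stated time of 72 h (on this read-out higher numbers stand for lower toxicity in this test and lower numbers for higher toxicity in this test), compound 2 `FC(F)(F)c1ccc(NCc2cn(-c3ccccc3)nc2-c2ccc(Br)cc2)cc1` gives 46000 nM, the only true number. Compound 1 `Brc1ccc(NCc2cn(-c3ccccc3)nc2-c2ccccc2)cc1` gives > 100000 nM, which is a limit of the assay. Compound 3 `Cc1ccc(-c2nn(-c3ccccc3)cc2CNc2ccc(C(F)(F)F)cc2)cc1` gives > 100000 nM, also a limit. Compound 4 `Brc1ccc(NCc2cn(-c3ccccc3)nc2-c2ccc(Br)cc2)cc1` has bromo in place of trifluoromethyl on an aromatic carbon. Among the measured compounds shown here, no measured step covers this exchange. The nearest, an at least 2.1-fold higher number from compound 2 to compound 3 (0.33 log units; beyond the scatter), replaces the bromo that compound 4 retains, so it bears only indirectly. The reading in this assay is capped by the limit of > 100000 nM in this assay, at which 2 of the 3 values shown sit. No step beyond the scatter is expected, and the estimated step is a 1.2-fold higher number from compound 2 to compound 4 (0.08 log units; within the scatter). For compound 4 the expected value is 55000 nM, with an estimated range of 28000 nM to 100000 nM.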

Compound 4, half-maximal cytotoxic concentration: > 100000 nM
Compound 4: only a limit was reported; the forecaster's own chance of this, stated with the estimate: 30%; middle value at least 1.8-fold (0.25 log units) from the limit.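

In this assay, the change from 4-(trifluoromethyl)phenyl to 4-bromophenyl gives an at least 2.1-fold higher number from compound 2 to compound 4 (0.33 log units; beyond the scatter), so the trifluoromethyl end of compound 2 counts in this read-out as well as the bromo exchanged in an at least 2.1-fold higher number from compound 2 to compound 3 (0.33 log units; beyond the scatter). As far as these compounds go, the full size of the new step stays unknown because the reading is capped: the limit of > 100000 nM in this assay, at which 3 of the 4 values shown sit. The step from compound 1 to compound 4 cannot be read; both values are limits.

Open, from the compounds shown here alone, is whether an amine or a carboxylic acid at this place would give a true number in this assay. Also open, going by these compounds, is whether a reading under the limit needs both the bromo and the trifluoromethyl of compound 2 together.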